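Notes on adding a 2-(tert-butoxycarbonyl)ethyl group

This account rests on a few compounds, and the source may have more. Where it says the series, first, only, none or still open, it means among the compounds named here.

In a functional assay (strain AB) with Danio rerio as the target, read by microscopy, with a stated time of 1 h (a lower number here means that less compound is needed, a higher number that more compound is needed for the effect), compound 1 `CC(C)CN1CCc2c(sc(NC(=O)Nc3ccc(Cl)cc3)c2C(N)=O)C1` gives 4510 nM and compound 2 `CCCN1CCc2c(sc(NC(=O)Nc3ccc(Cl)cc3)c2C(N)=O)C1` gives 3500 nM. Within the data shown here, these are the only two numbers so far, and they lie within the scatter of each other, so compound 2 stands level with compound 1.

Compound 3 `CC(C)(C)OC(=O)CCCCCN1CCc2c(sc(NC(=O)Nc3ccc(Cl)cc3)c2C(N)=O)C1` carries 2-(tert-butoxycarbonyl)ethyl in place of hydrogen on a saturated chain carbon, three bonds along the chain from an amine nitrogen in a ring.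

Among the measured compounds shown here, only one measured step bears on this change: a 1.3-fold lower number from compound 1 to compound 2 (0.11 log units; within the scatter). For the measured compounds named here, it exchanges only methyl and hydrogen, and no measured compound carries tert-butoxycarbonyl, so it offers weak guidance. No step beyond the scatter is expected, and no direction can be assigned with confidence. The expected change is a 1.1-fold higher number from compound 2 to compound 3 (0.06 log units; within the scatter).

In this assay the estimated value for compound 3 is 4000 nM, with an expected range of 1200 nM to 13000 nM.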

Compound 3, half-maximal effective concentration: 620 nM
The estimate for compound 3 lay 6.5-fold (0.81 log units) above the measured number, outside the stated range (below it).
By their numbers in this assay, from the lowest: compound 3; then compounds 2 and 1 (each within the scatter of the next).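

In this assay, the place on the saturated chain carbon, three bonds along the chain from an amine nitrogen in a ring, turns out to respond to substitution, which the earlier methyl to hydrogen step could not show: 2-(tert-butoxycarbonyl)ethyl there gives a clear step (a 5.6-fold lower number from compound 2 to compound 3 (0.75 log units; beyond the scatter)). The same holds against the branched compound: 4-(tert-butoxycarbonyl)butyl in place of isopropyl gives a step of similar reach (a 7.3-fold lower number from compound 1 to compound 3 (0.86 log units; beyond the scatter)), so compound 3 has the lowest number of the three. No measurement on hand explains the step.

The compounds shown leave open whether the lower number goes with the tert-butoxycarbonyl group or with the chain length alone. A longer plain alkyl chain, or a carboxylic acid or an amine at the chain end, would separate the two.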